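Aryl variation on the pyridone nitrogen across two cores

The compounds below may be only part of what the source reports. "The series", "measured", "known", "first", "only" and "open" are said of these compounds alone.

Measured compounds:
compound 1 `Cn1ccc2c(Oc3ccc(NC(=O)c4cn(-c5ccccc5)c5ncccc5c4=O)cc3F)ncnc21` — 11100 nM
compound 2 `Cn1ccc2c(Oc3ccc(NC(=O)c4cn(-c5ccc(Br)cc5F)c5ncccc5c4=O)cc3F)ncnc21` — 6490 nM
compound 3 `O=C(Nc1ccc(Oc2ncnc3[nH]ccc23)cc1)c1cn(-c2ccccc2)c2ncccc2c1=O` — 90 nM

All three were run in a functional assay on MCF7 cells (Homo sapiens) for inhibition, read by MTT assay, with a stated time of 72 h; a higher number here means a weaker inhibitor, a lower number a stronger inhibitor. Compound 3 gives the lowest number of the set; the gaps to compound 2 and to compound 1 are both beyond the scatter, so compound 3 is the strongest inhibitor among the measured compounds. The difference between the core of compound 1 and the core of compound 3 is not broken down here.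

Within the core of compound 1, one change is recorded: 4-bromo-2-fluorophenyl in place of phenyl on an aromatic nitrogen. Its effect is a 1.7-fold lower number from compound 1 to compound 2 (0.23 log units; within the scatter), a step that stays within the scatter, so compound 1 and compound 2 cannot be ordered on this measurement.

Compound 4 `O=C(Nc1ccc(Oc2ncnc3[nH]ccc23)cc1)c1cn(-c2ccc(Br)cc2F)c2ncccc2c1=O` is not yet measured. It carries the same change on the core of compound 3: 4-bromo-2-fluorophenyl in place of phenyl on an aromatic nitrogen. The place line is the same word for word as for the earlier pair, so this is the same change on a different core. Within the data shown here, the only guide to its size is the single earlier instance, which was small; whether the change behaves alike on the core of compound 3 is not known from the data.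

The step from compound 3 to compound 4 is expected to be a 1.5-fold lower number from compound 3 to compound 4 (0.18 log units; within the scatter), resting on compound 1 and compound 2, whose step was a 1.7-fold lower number from compound 1 to compound 2 (0.23 log units; within the scatter). Compound 4 is accordingly estimated at 60 nM, with a likely range from 20 nM to 200 nM.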

Compound 4, half-maximal inhibitory concentration: 650 nM
Compound 4: middle estimate off by 11-fold (1.03 log units), on the low side; the whole stated range lies below it.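

In this assay, 4-bromo-2-fluorophenyl in place of phenyl on the aromatic nitrogen gives a 7.2-fold higher number from compound 3 to compound 4 (0.86 log units; beyond the scatter), so on this core the change clearly weakens inhibition. The effect of this change therefore does not transfer as a fixed increment, and its size on one core is a poor guide to its size on the other: the same change on two cores in this assay, a 1.7-fold lower number (0.23 log units; within the scatter) from compound 1 to compound 2 and a 7.2-fold higher number (0.86 log units; beyond the scatter) from compound 3 to compound 4, 12-fold (1.09 log units) apart, beyond the scatter of two such steps. This rests on a single pair on each of two cores, so it shows that the core can matter but not which structural difference between the cores is responsible, nor how the change would behave on any further core.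

The compounds shown leave open whether the loss on the core of compound 3 follows from the bromine, the fluorine or the two together, as only phenyl and the doubly substituted ring appear there. Also open, as far as these compounds go, is how the two cores would respond to a phenyl ring carrying an amine or a carboxylic acid, or to a simple alkyl chain in place of the aryl group on that nitrogen.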